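Iodo in place of cyclohexyl: a first look

The source may hold more compounds than are shown below. What is called first, only, known or untested is meant among the compounds shown, and "the series" means these compounds.

In a functional assay on M21 cells (Homo sapiens) for inhibition, read by sulforhodamine B assay, with a stated time of 48 h (on this read-out higher numbers stand for weaker inhibition of growth and lower numbers for stronger inhibition of growth), compound 1 (`c1cc(C2CCCCC2)ccc1NC1=NCCO1`) gives 17800 nM and compound 2 (`c1cc(NC2=NCCO2)cc(OC2CCCCC2)c1`) gives 12000 nM. Among the compounds with values here, these two values lie within the scatter of each other, so compound 1 stands level with the only other measured compound. Compound 3 (`Ic1ccc(NC2=NCCO2)cc1`) carries iodo in place of cyclohexyl on an aromatic carbon. Within the data shown here, no measured pair isolates this change, so the data offer no direct guide. No shift beyond the scatter is expected in this assay. The estimated step is a 1.1-fold higher number from compound 1 to compound 3 (0.05 log units; within the scatter). Compound 3 is expected at 20000 nM, with an estimated range of 7000 nM to 60000 nM.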

Compound 3, concentration for 50% growth inhibition: 2000 nM
The estimate for compound 3 lay 10-fold (1.00 log units) above the measured number; measured number below the stated range.
By their numbers in this assay, from the lowest: compound 3; then compounds 2 and 1 (each within the scatter of the next).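

Iodo in place of cyclohexyl on an aromatic carbon gives an 8.9-fold lower number from compound 1 to compound 3 (0.95 log units; beyond the scatter) in this assay, so the group at this place can move the growth-inhibition read-out beyond the scatter. Within the data shown here, no earlier measured pair isolated this place. The finding rests on this single pair, and nothing measured here bears on what lies behind the step.

From the compounds shown here alone, whether the step is specific to iodo remains open, and a chloro, a bromo, a methyl or an amine on the same aromatic carbon would help to settle that. Whether it also holds in other cell lines is equally unresolved.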